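Adding a Phenyl Group in a Cytotoxicity Series

The source may report more compounds than this note shows. Statements on the series, on what has been measured and on what is new or still open speak of the compounds shown alone.

The measured compounds and their values:
compound 1, `O=C(CCCCC1CCSS1)NCc1cn(CCCOc2ccc3ccc(=O)oc3c2)nn1`, 39.2%
compound 2, `O=C(CCCCC1CCSS1)NCc1cn(CCCOc2ccc3cc(-c4ccccc4)c(=O)oc3c2)nn1`, 29.8%
compound 3, `O=C(CCCCC1CCSS1)NCc1cn(CCCCOc2ccc3ccc(=O)oc3c2)nn1`, 52.8%

All three were tested in a functional assay on PC-12 cells (Rattus norvegicus) for cytotoxicity, read by MTT assay, with stated times of 3 h and 2 h, tested at 5 uM; on this read-out higher numbers stand for a stronger effect at the one concentration tested and lower numbers for a weaker effect. Compound 1 and compound 2 share a core and differ in one place: phenyl in place of hydrogen on an aromatic carbon. That change made a number 9.4 percentage points lower from compound 1 to compound 2 (within the scatter), so the two numbers cannot be told apart with confidence.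

Compound 3 gives the highest of the three numbers, beyond the scatter from both compound 1 and compound 2. How its core differs from the core of compound 1 is not broken down here.

Compound 4, `O=C(CCCCC1CCSS1)NCc1cn(CCCCOc2ccc3cc(-c4ccccc4)c(=O)oc3c2)nn1`, has not yet been measured. It differs from compound 3 in one place: phenyl in place of hydrogen on an aromatic carbon. This is the same change, in the same surroundings, as the one from compound 1 to compound 2, and it occurs twice among the compounds shown. Within the data shown here, the only guide to its effect is that earlier pair. Because that earlier step was a number 9.4 percentage points lower from compound 1 to compound 2 (within the scatter), the step expected here is a number 9.8 percentage points lower from compound 3 to compound 4 (within the scatter), again within the scatter. On that basis compound 4 is expected to give about 43% in this assay, with a likely range from 30% to 56%. Whether a measurement will bear this out remains to be seen.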

Compound 4, a percentage reported as activity, at one concentration (the size of the read-out at that concentration, not a potency): 32.8%
Estimate against measurement, compound 4: 10.2 percentage points above, and the stated range covers the measured number.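

On the core of compound 3, phenyl in place of hydrogen on an aromatic carbon gave a number 20 percentage points lower from compound 3 to compound 4 (beyond the scatter) in this assay, a step that, unlike the earlier one, stands clear of the usual scatter on its own. Set side by side, the two steps cannot be told apart in size: the same change on two cores in this assay, a number 9.4 percentage points lower (within the scatter) from compound 1 to compound 2 and a number 20 percentage points lower (beyond the scatter) from compound 3 to compound 4, 10.6 percentage points apart, within the scatter of two such steps So the result fits the idea that this change carries over from one core to the other with a similar effect, but it does not prove that the effect is the same, as it rests on only two pairs of compounds, each read at a single concentration, and it says nothing about any other core.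

The compounds shown leave open whether a different group on the same aromatic carbon, such as a methyl or an amine, would shift the number in a similar way, or whether phenyl itself is needed for the step. Among these compounds, they also leave open whether the phenyl step would hold up on a core with a longer chain than the one in compound 3.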